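The compounds below may be only part of what the source reports. "The series", "measured", "known", "first", "only" and "open" are said of these compounds alone.

Compound 1, `Nc1nc(O)c2c(n1)n(C1OC(CO)[C@@H](O)[C@H]1O)c(=O)n2C/C=C/c1ccccc1`, in a functional assay on the whole organism (B cells) with Mus musculus as the target; on this read-out lower numbers stand for smaller maximal responses and higher numbers for larger maximal responses: 73%
Compound 2, `Nc1nc(O)c2c(n1)n(C1OC(CO)[C@@H](O)[C@H]1O)c(=O)n2Cc1ccc(Cl)c(Cl)c1`, in this assay: 55%

Within the data shown here, compound 2 stands lowest of the two numbers known so far; its nearest neighbour is compound 1, and the step of a number 18 percentage points lower from compound 1 to compound 2 (beyond the scatter) lies beyond the scatter. Compound 3, `[N-]=[N+]=NCC(O)Cn1c(=O)n(C2OC(CO)[C@@H](O)[C@H]2O)c2nc(N)nc(O)c21`, has not yet been measured. It differs from compound 2 by 2-azido-1-hydroxyethyl in place of 3,4-dichlorophenyl on a saturated chain carbon bound to an aromatic nitrogen.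

Among the measured compounds shown here, only one measured step exists, and it replaces one aromatic group by another on the same chain carbon; no measured pair exchanges an aromatic group for a chain such as 3-azido-2-hydroxypropyl. The step from compound 1 to compound 2 is therefore only a loose guide to the size of change such a substitution can bring. A modest step in either direction, or none beyond the scatter, is expected for compound 3, with the step estimated as a number 5 percentage points higher from compound 2 to compound 3 (within the scatter). The value for compound 3 is estimated at 60%, with a range from 35% to 85%.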

Compound 3, largest response reached (reported as maximal response), in percent of the reference or control that the assay uses: 91%
Compound 3: middle estimate off by 31 percentage points, on the low side; measured number outside the range, above it.
By their numbers in this assay, from the lowest: compound 2; then compound 1; then compound 3.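

On the saturated chain carbon bound to an aromatic nitrogen, a ring is not needed for a large response in this assay: 2-azido-1-hydroxyethyl in place of 3,4-dichlorophenyl brings a number 36 percentage points higher from compound 2 to compound 3 (beyond the scatter), a large step. The same group in place of 2-phenylethenyl brings a number 18 percentage points higher from compound 1 to compound 3 (beyond the scatter), so compound 3 stands highest of the three, with both ring-bearing compounds below it. Nothing available explains why this exchange raises the response.

The azido and hydroxy parts of the new group enter together, so the compounds shown do not tell which of them carries the rise. A 3-amino-2-hydroxypropyl chain, or a plain propyl chain, on the same carbon would be needed to separate the two parts.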